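Swapping the Furan for a Pyridine on the Amide Carbonyl

The compounds below may be only part of what the source reports. "The series", "measured", "known", "first", "only" and "open" are said of these compounds alone.

Compound 1 `CC(C)C[C@H](NC(=O)c1ccc2ccccc2n1)C(=O)N[C@H]1CCN(Cc2ccc(OCCCN(C)C)cc2)C1`: 631 nM
Compound 2 `CC(C)C[C@H](NC(=O)c1ccc(Br)cc1)C(=O)N[C@H]1CCN(Cc2ccc(OCCCN(C)C)cc2)C1`: 200 nM
Compound 3 `CC(C)C[C@H](NC(=O)c1ccco1)C(=O)N[C@H]1CCN(Cc2ccc(OCCCN(C)C)cc2)C1`: 631 nM

Within the data shown here, in an assay on HEK293 cells for binding affinity to Urotensin-2 receptor (Homo sapiens), read by radioligand binding (on this read-out higher numbers stand for weaker inhibition and lower numbers for stronger inhibition), compound 3 sits level with compound 1, the two together giving the highest numbers of the three, while the only step that separates them from compound 2 is a 3.2-fold higher number from compound 2 to compound 3 (0.50 log units; beyond the scatter). Compound 4 `CC(C)C[C@H](NC(=O)c1ccncc1)C(=O)N[C@H]1CCN(Cc2ccc(OCCCN(C)C)cc2)C1` carries pyridin-4-yl in place of furan-2-yl on a carbonyl carbon. Among the measured compounds shown here, two measured steps bear on this: no change at the digits printed from compound 1 to compound 3 (within the scatter), where another nitrogen-containing aromatic ring was exchanged for the furan without effect, and a 3.2-fold higher number from compound 2 to compound 3 (0.50 log units; beyond the scatter), a modest rise when a six-membered ring gave way to the furan. A six-membered ring returns in compound 4, so a small fall at most is expected, a 1.4-fold lower number from compound 3 to compound 4 (0.15 log units; within the scatter). Compound 4 is therefore estimated at 450 nM, in the range 150 nM to 1400 nM.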

Compound 4, inhibition constant: 2000 nM
Compound 4: middle estimate off by 4.4-fold (0.65 log units), on the low side; the measured number lies above the stated range.
By their numbers in this assay, from the lowest: compound 2; then compounds 1 and 3 (each within the scatter of the next); then compound 4.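

In this assay pyridin-4-yl on the carbonyl gives the highest number of the four, with a 3.2-fold higher number from compound 3 to compound 4 (0.50 log units; beyond the scatter) and a 3.2-fold higher number from compound 1 to compound 4 (0.50 log units; beyond the scatter) and also a 10-fold higher number from compound 2 to compound 4 (1.00 log units; beyond the scatter) as the widest gap. Compound 2 and compound 4 both carry a six-membered aromatic ring at this position, yet they lie far apart, so ring size alone does not set the number. Nothing measured here gives a reason for this rise. A plain phenyl group at the same place would help show whether the bromine of compound 2 or the ring nitrogen of compound 4 matters more.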